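Swapping furan-3-yl for phenyl on compound 2

The source may report more compounds than this note shows. Statements on the series, on what has been measured and on what is new or still open speak of the compounds shown alone.

In a functional assay on HepG2 cells (Homo sapiens) for antiproliferative activity, read by XTT assay, with a stated time of 72 h (on this read-out higher numbers stand for weaker inhibition and lower numbers for stronger inhibition), compound 1 `COc1ncnc2c1c(-c1cc3ccccc3o1)cn2[C@@H]1O[C@H](CO)[C@@H](O)[C@H]1O` gives > 20000 nM as a limit and not a number. Compound 2 `CSc1ncnc2c1c(-c1ccoc1)cn2[C@@H]1O[C@H](CO)[C@@H](O)[C@H]1O` stands at > 15000 nM which is likewise only a limit. Compound 3 `CSc1ncnc2c1c(-c1ccccc1)cn2[C@@H]1O[C@H](CO)[C@@H](O)[C@H]1O` differs from compound 2 in one place phenyl in place of furan-3-yl on an aromatic carbon with phenyl in place of furan-3-yl on an aromatic carbon. Going by the values given here, no measured step shows what such a swap does, so no change beyond the usual scatter is expected in this assay here. The expected size is a step that the limit leaves unreadable from compound 2 to compound 3 in this estimate. Compound 3 is expected at 20000 nM and the estimated range runs from 8000 nM to 50000 nM for it.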

Compound 3, half-maximal inhibitory concentration: > 20000 nM
Compound 3 ended at the assay's limit (the forecaster's own chance of this, stated with the estimate: 75%); the middle value sits exactly at the limit.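

Compound 2 and compound 3 each give only a limit of the assay and not a number, and no step can be read between them. The compounds shown leave open how phenyl and furan-3-yl compare at this place on the shared core.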